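Chlorinated phenol replaces the fluoromethoxy ring on the chain

A few compounds are considered here, and "the series" means these few. Any claim that something is new, unique, unknown or untested is made for them only; others in the source may bear on it.

Compound 1 `COc1ccc(/C=C/C(=O)c2ccc(OC)c3c2OC(C)(C)C=C3)c(F)c1` was examined in a functional assay on HT-29 cells (Homo sapiens) for antiproliferative activity, read by MTT assay, with a stated time of 24 h; on this read-out higher numbers stand for weaker inhibition and lower numbers for stronger inhibition. In this assay compound 1 returns only the limit > 10000 nM. Compound 2 `COc1ccc(C(=O)/C=C/c2cccc3ccccc23)c2c1C=CC(C)(C)O2` likewise stops at the limit > 10000 nM. Compound 3 `COc1ccc(C(=O)/C=C/c2cccc(O)c2)c2c1C=CC(C)(C)O2` also gives only the limit > 10000 nM. The step from compound 1 to compound 3 is therefore a step that the two limits leave unreadable from compound 1 to compound 3, because of the limit of > 10000 nM in this assay, at which 3 of the 3 values shown sit. Compound 4 `COc1ccc(C(=O)/C=C/c2cc(Cl)ccc2O)c2c1C=CC(C)(C)O2` carries the change (5-chloro-2-hydroxyphenyl in place of 2-fluoro-4-methoxyphenyl on a double-bonded chain carbon bound to a double-bonded chain carbon). No readable measured step bears on this change, so the data give no size and no direction to expect in this assay. The step is expected to be a step that the limit leaves unreadable from compound 1 to compound 4. Compound 4 is estimated at 15000 nM, in a range from 4000 nM to 60000 nM, most likely again reported as a limit.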

Compound 4, half-maximal inhibitory concentration: 4970 nM
Compound 4: the middle estimate sits 3.0-fold (0.48 log units) above what was measured; measured number inside the range.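

In this assay compound 4 is the only compound shown that returns a number rather than a limit, so 5-chloro-2-hydroxyphenyl is the first group at this place on the chain with a readable value. The change gives an at least 2.0-fold lower number from compound 1 to compound 4 (0.30 log units; that floor lies within the scatter), and exchanging 3-hydroxyphenyl for the same group gives an at least 2.0-fold lower number from compound 3 to compound 4 (0.30 log units; that floor lies within the scatter). Both are floors, and the full size of each step stays unknown: the limit of > 10000 nM in this assay, at which 3 of the 4 values shown sit.

The compounds shown leave open how the chlorine and the hydroxy group each contribute to this value. They also leave open what an amine or a carboxylic acid in place of the chlorine would give.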